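Dropping the methoxy group from compound 2

A few compounds are considered here, and "the series" means these few. Any claim that something is new, unique, unknown or untested is made for them only; others in the source may bear on it.

Measured so far:
compound 1 `COc1cccc(C(F)(F)F)c1C(=O)NC1(c2ccccc2)CCCN(C)C1` gives 1500 nM in an assay on cells for inhibition of sodium- and chloride-dependent glycine transporter 1 (Homo sapiens); a higher number here means that more compound is needed for the effect, a lower number that less compound is needed;
compound 2 `COc1cc(C(F)(F)F)ccc1C(=O)NC1(c2ccccc2)CCCN(C)C1` gives 4800 nM in this assay.

Compound 2 stands at the highest number of the two, meaning more of it is needed than of compound 1, and the gap between them lies beyond the usual scatter. Compound 3 `CN1CCCC(NC(=O)c2ccc(C(F)(F)F)cc2)(c2ccccc2)C1` differs from compound 2 in one place: hydrogen in place of methoxy on an aromatic carbon. Among the compounds with values here, no directly comparable pair of measured compounds shows what this change does, so the expectation rests only on the values of compound 2 and compound 1. The step is expected to be small, most likely toward a slightly higher number, a 1.4-fold higher number from compound 2 to compound 3 (0.13 log units; within the scatter). Compound 3 is therefore estimated at 6500 nM, with a range from 2500 nM to 18000 nM.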

Compound 3, half-maximal effective concentration: > 10000 nM
Compound 3 gave a limit, no number; the forecaster's own chance of this, stated with the estimate: 10%; middle value at least 1.5-fold (0.18 log units) from the limit.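

In this assay compound 3 gives > 10000 nM, which is a limit of the assay and not a number. Even so, it shows for the first time that this position matters: putting hydrogen in place of methoxy, on the aromatic carbon ortho to a large group, gives an at least 2.0-fold higher number from compound 2 to compound 3 (0.31 log units; beyond the scatter). Less compound is therefore needed with the methoxy group present than without it.

Going by these compounds, the full size of this step remains open. The compounds shown also leave open whether a methyl group, a hydroxyl group or a chlorine atom on this carbon would match methoxy.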